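Bromo for chloro: a second exchange on the shared core

A few compounds are considered here, and "the series" means these few. Any claim that something is new, unique, unknown or untested is made for them only; others in the source may bear on it.

Of the compounds shown here, three have been measured in an assay on isolated protein for inhibition of Calpain-1 catalytic subunit (Sus scrofa), read by FRET; on this read-out lower numbers stand for stronger inhibition and higher numbers for weaker inhibition. Compound 1, `O=C(O)/C(S)=C/c1c[nH]c2cc(Br)ccc12`, gives 7 nM. Compound 2, `O=C(O)/C(S)=C/c1c[nH]c2cc(Cl)ccc12`, gives 210 nM. Compound 3, `O=C(O)/C(S)=C/c1c[nH]c2cccc(Cl)c12`, gives 20 nM; it stands second highest of the three, nearer to compound 1 than to compound 2.

One measured pair differs in a single place: bromo in place of chloro on an aromatic carbon. This gave a 30-fold lower number from compound 2 to compound 1 (1.48 log units; beyond the scatter). The difference between the core of compound 2 and the core of compound 3 is not broken down here; the two hold the same atoms, joined differently, and their values in this assay stand as given above.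

Compound 4, `O=C(O)/C(S)=C/c1c[nH]c2cccc(Br)c12`, has not yet been measured. It differs from compound 3 as bromo in place of chloro on an aromatic carbon. Within the data shown here, this is the same kind of change as the one from compound 2 to compound 1, but not the same: the leaving and entering groups agree, while the place differs, being ortho to a fused ring and meta to a fused ring in compound 4 against meta to a fused ring and para to a fused ring in compound 1.

Among the measured compounds shown here, because a 30-fold lower number from compound 2 to compound 1 (1.48 log units; beyond the scatter) was found for the one measured exchange of this kind, a lower number is expected for compound 4 than for compound 3, though a smaller step is assumed, that exchange being made at a different place and standing alone as a precedent, so the step is estimated at a 2.5-fold lower number from compound 3 to compound 4 (0.40 log units; beyond the scatter). In this assay compound 4 is accordingly expected to give 8 nM, with a range from 2 nM to 30 nM.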

Compound 4, half-maximal inhibitory concentration: 6 nM
Beside the measured number, compound 4's estimate is 1.3-fold (0.12 log units) above it, and the stated range covers the measured number.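

In this assay, bromo in place of chloro on an aromatic carbon again gives a lower number, a 3.3-fold lower number from compound 3 to compound 4 (0.52 log units; beyond the scatter), so the direction of the step holds on both cores shown. The size of the step does not carry from one core to the other, and a step read on one core cannot be used as a measure of the step on the other: the same change on two cores in this assay, a 30-fold lower number (1.48 log units; beyond the scatter) from compound 2 to compound 1 and a 3.3-fold lower number (0.52 log units; beyond the scatter) from compound 3 to compound 4, 9.0-fold (0.95 log units) apart, beyond the scatter of two such steps. These two pairs show only that the direction agreed in this series; they do not show what sets the size of the step, whether the place of the halogen or some other difference between the cores accounts for the gap, or whether the direction would hold on any further core.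

Open, as far as these compounds go, is whether an iodo or a fluoro group at either of the two places would extend the order seen for chloro and bromo, and whether a methyl group or a nitrile there would give numbers of a similar kind. Also open is how the halogen exchange would behave with a methyl ester in place of the carboxylic acid, since the carboxylic acid and the thiol stay the same throughout the four compounds shown.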